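Adding a trifluoromethyl group to the strongest EP3 binder

The source may report more compounds than this note shows. Statements on the series, on what has been measured and on what is new or still open speak of the compounds shown alone.

Of the compounds shown here, three have been measured in an assay on CHO cells for displacement of a labelled ligand from prostaglandin E2 receptor EP3 subtype (Mus musculus), read by scintillation counting, with a stated time of 60 min; a higher number here means a weaker inhibitor, a lower number a stronger inhibitor. Compound 1 `O=C(O)CCCSCCN1C(=O)OC[C@@H]1/C=C/[C@@H](O)Cc1ccccc1` gives 6400 nM, and compound 2 `CCCc1cccc(C[C@H](O)/C=C/[C@H]2CCC(=S)N2CCCCCCC(=O)O)c1` gives 2000 nM. Compound 3 `O=C(O)CCCSCCN1C(=O)SC[C@@H]1/C=C/[C@@H](O)Cc1ccccc1` gives 39 nM, the lowest number of the three; its nearest neighbour is compound 2, whose number is higher by an amount beyond the scatter, and compound 1 lies further away still. Compound 3 is therefore the strongest inhibitor among the measured compounds.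

Compound 4 `O=C(O)CCCSCCN1C(=O)SC[C@@H]1/C=C/[C@@H](O)Cc1cccc(C(F)(F)F)c1` has not yet been measured. It differs from compound 3 in one place: trifluoromethyl in place of hydrogen on an aromatic carbon. For the measured compounds named here, no pair of measured compounds differs in the same way, so there is no measured step to lean on; the expectation rests on compound 3 alone, whose value in this assay is 39 nM. A group of this kind on the aromatic ring is expected to shift the number a little downward, by less than the gap between compound 3 and compound 2, but the shift may well stay within the scatter. The step from compound 3 to compound 4 is thus estimated as a 1.6-fold lower number from compound 3 to compound 4 (0.19 log units; within the scatter). Compound 4 is expected to give about 25 nM in this assay, most likely between 8 nM and 80 nM.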

Compound 4, inhibition constant: 280 nM
The estimate for compound 4 lay 11-fold (1.05 log units) below the measured number, outside the stated range (above it).
By their numbers in this assay, from the lowest: compound 3; then compound 4; then compound 2; then compound 1.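

In this assay, the change from phenyl to 3-(trifluoromethyl)phenyl brings a 7.2-fold higher number from compound 3 to compound 4 (0.86 log units; beyond the scatter) and gives the first measured step in this set, so the aromatic ring of compound 3 is shown not to be indifferent to substitution at this place. The direction is upward: at this aromatic carbon, meta to a large group, trifluoromethyl weakens binding relative to hydrogen, while compound 4 remains in the nanomolar range at 280 nM. Nothing among the data shown explains why the number rises.

From the compounds shown here alone, a single step cannot separate the effect of this particular group from that of any substituent at this place, so it remains open whether a fluorine atom, a chlorine atom, a methyl group or a methoxy group would be tolerated better here. Going by these compounds, it also remains open whether the same change would have a similar effect at another aromatic carbon of the ring, or on the core of compound 1, whose ring oxygen stands where compound 3 has sulfur.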